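Side-chain variation on a shared core, cytotoxicity

The compounds below may be only part of what the source reports. "The series", "measured", "known", "first", "only" and "open" are said of these compounds alone.

The series keeps the core seen in compound 1 `C/C(=C\Cc1c(O)ccc2c1O[C@H](c1ccc(O)cc1)CC2=O)C/C=C/C(C)(C)O` and varies the chain on a saturated chain carbon bound to an aromatic carbon. In a functional assay on MCF7 cells (Homo sapiens) for cytotoxicity, read by MTT assay (on this read-out higher numbers stand for weaker inhibition and lower numbers for stronger inhibition), compound 1 gives > 10000 nM, which is a limit of the assay and not a number. Compound 2 `COC(C=C(C)C)C/C(C)=C/Cc1c(O)ccc2c1O[C@H](c1ccc(O)cc1)CC2=O` in this assay gives > 10000 nM, again only a limit. Compound 3 `CC1=CCC(O)C(C)(C)C1Cc1c(O)ccc2c1O[C@H](c1ccc(O)cc1)CC2=O` in this assay gives > 10000 nM, also a limit. Compound 3 therefore stands with the rest of the set at the limit of > 10000 nM in this assay, at which 3 of the 3 values shown sit. The two measured steps, a step that the two limits leave unreadable from compound 1 to compound 2 and a step that the two limits leave unreadable from compound 1 to compound 3, stay unreadable in size for that reason, and neither gives a usable direction.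

Compound 4 `CC(C)=CCC/C(C)=C/Cc1c(O)ccc2c1O[C@H](c1ccc(O)cc1)CC2=O` differs from compound 3 by 2,6-dimethylhepta-1,5-dien-1-yl in place of 5-hydroxy-2,6,6-trimethylcyclohex-2-en-1-yl on a saturated chain carbon bound to an aromatic carbon. Going by the values given here, no measured step with a readable size bears on this change, and every value so far sits at the limit. Compound 4 is expected to stay at the limit as well, with an estimated step that the limit leaves unreadable from compound 3 to compound 4 that cannot be resolved. For compound 4 the estimate is 20000 nM, with an expected range from 8000 nM to 60000 nM.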

Compound 4, half-maximal inhibitory concentration: > 10000 nM
Compound 4: a limit, no number; the forecaster's own chance of this, stated with the estimate: 80%; the middle value is on the limit's open side.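

Compound 4 gives > 10000 nM in this assay, again a limit and not a number. Its steps from compound 1, compound 2 and compound 3 therefore cannot be read: the limit of > 10000 nM in this assay, at which 4 of the 4 values shown sit.

The compounds shown leave open whether any chain at this place on the shared core gives a measurable value in this assay.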